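The compounds below may be only part of what the source reports. "The series", "measured", "known", "first", "only" and "open" are said of these compounds alone.

Working notes on the series. Compound 1 `O=C(Nc1cccc(-n2cc(-c3ccncc3)c(-c3cc(O)cc(Cl)c3)n2)c1)Nc1ccc(Cl)c(C(F)(F)F)c1` gives -38% in a functional assay on CAKI-1 cells (Homo sapiens) for inhibition, read by sulforhodamine B assay, with a stated time of 48 h, tested at 100 uM; a lower number here means a stronger effect, a higher number a weaker effect of the compound at the concentration tested. For the measured compounds named here, compound 2 `O=C(Nc1cccc(-n2cc(-c3ccncc3)c(-c3cc(O)cc(Cl)c3)n2)c1)Nc1ccc(Cl)c(Cl)c1` gives -12% in this assay; the step of a number 26 percentage points higher from compound 1 to compound 2 (beyond the scatter) is the only measured step in the set. Compound 3 `COc1cc(Cl)cc(-c2nn(-c3cccc(NC(=O)Nc4cc(C(F)(F)F)cc(C(F)(F)F)c4)c3)cc2-c2ccncc2)c1`, with a methoxy in place of the hydroxy on the shared core and two trifluoromethyl groups on the urea-linked ring, gives -61% in this assay and stands lowest of the three numbers, beyond the scatter from both compound 1 and compound 2, so it is the strongest of the measured compounds.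

Compound 4 `COc1cc(Cl)cc(-c2nn(-c3cccc(NC(=O)Nc4cccc(C(F)(F)F)c4)c3)cc2-c2ccncc2)c1` is not yet measured. It differs from compound 3 by hydrogen in place of trifluoromethyl on an aromatic carbon.

Going by the values given here, the only step that bears on this change is the one from compound 1 to compound 2, where a chloro replaced a trifluoromethyl on the same urea-linked ring and the number rose by a number 26 percentage points higher from compound 1 to compound 2 (beyond the scatter), a weaker effect. Loss of a trifluoromethyl altogether is a larger change in the same sense, and no measured step shows removal of the group outright. A step of moderate size toward a higher number, beyond the scatter, is therefore expected for compound 4, a number 26 percentage points higher from compound 3 to compound 4 (beyond the scatter). Compound 4 is estimated at -35%, with a range from -65% to -5%, the lower end covering the case that the remaining trifluoromethyl carries most of the effect.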

Compound 4, a percentage reported as activity, at one concentration (the size of the read-out at that concentration, not a potency): -20%
Compound 4: the middle estimate sits 15 percentage points below what was measured; low and high end bracket the measured number.
By their numbers in this assay, from the lowest: compound 3; then compound 1; then compounds 4 and 2 (each within the scatter of the next).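

In this assay, for the compounds shown here, the step of a number 41 percentage points higher from compound 3 to compound 4 (beyond the scatter) is the first in the set to show the outright loss of a trifluoromethyl group from the urea-linked ring, rather than its exchange for chloro. This step is rated large, whereas the step of a number 26 percentage points higher from compound 1 to compound 2 (beyond the scatter) is rated modest, so on this ring the effect at this concentration depends on what occupies the aromatic carbon, and the trifluoromethyl group that remains in compound 4 does not keep the number of compound 3. Nothing on hand gives a reason for the size of this step.

The compounds shown leave open whether a small group such as methyl, fluoro, methoxy or an amine on this aromatic carbon would keep the number near that of compound 3 or sit nearer that of compound 4. Going by these compounds alone, they also leave open whether the same loss of trifluoromethyl would give a step of similar size on the hydroxy form of the shared core, and what the methoxy itself contributes, as no pair here differs at that place alone.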